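The source may hold more compounds than are shown below. What is called first, only, known or untested is meant among the compounds shown, and "the series" means these compounds.

In a functional assay on A549 cells (Homo sapiens) for inhibition, read by MTT assay, with a stated time of 48 h (a higher number here means a weaker inhibitor, a lower number a stronger inhibitor), compound 1 `O=C1N/C(=N\Cc2ccccc2)S/C1=C1/CCNC(=O)c2[nH]ccc21` gives 26900 nM, and compound 2 `COc1ccc(C/N=C2\NC(=O)/C(=C3\CCNC(=O)c4[nH]ccc43)S2)cc1` gives 18300 nM. The methoxy change is a 1.5-fold lower number from compound 1 to compound 2 (0.17 log units; within the scatter). Compound 3 `O=C1N/C(=N\Cc2ccc(Cl)cc2)S/C1=C1/CCNC(=O)c2[nH]ccc21` is the only one of the three reported as a limit, > 100000 nM, and this is not a number. Both steps into it are beyond the scatter: an at least 3.7-fold higher number from compound 1 to compound 3 (0.57 log units; beyond the scatter) for chloro in place of hydrogen, and an at least 5.4-fold higher number from compound 2 to compound 3 (0.73 log units; beyond the scatter) for chloro in place of methoxy.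

Compound 4 `O=C1N/C(=N\Cc2ccccc2Cl)S/C1=C1/CCNC(=O)c2[nH]ccc21` has the same atoms joined differently: 2-chlorophenyl in place of 4-chlorophenyl on a saturated chain carbon bound to a double-bonded nitrogen. Going by the values given here, no measured step tests this change directly. The two steps into compound 3 bear on it most, since they show that a chloro group on the aromatic ring can shift the number beyond the scatter, whereas a 1.5-fold lower number from compound 1 to compound 2 (0.17 log units; within the scatter) shows a substituent that does not. A modest move back toward compound 1, at 26900 nM, therefore seems likely. Compound 4 may also stay at the limit. In this assay the expected change is an at least 2.2-fold lower number from compound 3 to compound 4 (0.34 log units; beyond the scatter), towards a lower number. For compound 4 the estimated value is 45000 nM, with an expected range of 15000 nM to 100000 nM.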

Compound 4, half-maximal inhibitory concentration: > 100000 nM
Compound 4: no number, only a limit; the forecaster's own chance of this, stated with the estimate: 30%; middle value at least 2.2-fold (0.34 log units) away from the limit.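

Compound 4 gives > 100000 nM in this assay, which is a limit of the assay and not a number. The shift seen with 4-chlorophenyl is therefore not confined to that group, since 2-chlorophenyl also gives an at least 3.7-fold higher number from compound 1 to compound 4 (0.57 log units; beyond the scatter) and an at least 5.4-fold higher number from compound 2 to compound 4 (0.73 log units; beyond the scatter). The step between compound 3 and compound 4 cannot be read, so moving the chloro group shows no measurable difference here, and both compounds stand at the same limit: the limit of > 100000 nM in this assay, at which 2 of the 4 values shown sit.

Which of the two chloro placements lies further from compound 1 remains open. Also open, on these data alone, is whether a bromo group or an amine in place of the chloro group would give a readable number or stay at the limit.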